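This account rests on a few compounds, and the source may have more. Where it says the series, first, only, none or still open, it means among the compounds named here.

Measured compounds in a functional assay on SGC-7901 cells (Homo sapiens) for inhibition, read by MTT assay, with a stated time of 48 h; a higher number here means a weaker inhibitor, a lower number a stronger inhibitor:
Compound 1 `Cc1nnsc1CO/N=C/c1c(C)nn(C)c1Oc1ccccc1Cl` gives > 50000 nM in this assay, a limit of the assay.
Compound 2 `Cc1nnsc1CO/N=C/c1c(C)nn(C)c1Oc1cccc(C(F)(F)F)c1` gives 12400 nM in this assay.
Compound 3 `Cc1nnsc1CO/N=C/c1c(C)nn(C)c1Oc1ccc(F)cc1` gives > 50000 nM in this assay, a limit of the assay.

Compound 3 thus stands at the limit, with no number behind it; it shares that position with compound 1, as noted in the limit of > 50000 nM in this assay, at which 2 of the 3 values shown sit. Within the data shown here, the only measured step reaching compound 3, a step that the two limits leave unreadable from compound 1 to compound 3, is unreadable because both ends are limits. Among the measured compounds shown here, compound 2 is the one member of the series with a numerical value, showing that a change on the phenoxy ring can bring the series into the readable range; no step to compound 2 is available for comparison.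

Compound 4 `Cc1nnsc1CO/N=C/c1c(C)nn(C)c1Oc1ccc(I)cc1` differs from compound 3 by iodo in place of fluoro on an aromatic carbon. For the measured compounds named here, no measured step bears directly on this change, so no size can be carried over. Compound 4 is expected to sit near the limit, with an estimate of 30000 nM (range 8000 nM to 60000 nM), which is estimated to mean a step of an at least 1.6-fold lower number from compound 3 to compound 4 (0.22 log units; that floor lies within the scatter) from compound 3, uncertain in both size and direction.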

Compound 4, half-maximal inhibitory concentration: > 50000 nM
Compound 4 gave a limit, no number (the forecaster's own chance of this, stated with the estimate: 50%); middle value at least 1.6-fold (0.22 log units) from the limit.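

No new step can be read: compound 1, compound 3 and compound 4 all give limits, not numbers, so the steps among them cannot be sized, with the series resting on one value: the limit of > 50000 nM in this assay, at which 3 of the 4 values shown sit.

Left open is how strongly these three compounds inhibit in this assay, and so what iodo in place of fluoro does.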